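The source may hold more compounds than are shown below. What is called first, only, known or untested is meant among the compounds shown, and "the series" means these compounds.

Measured compounds in this set:
compound 1 `Cc1c(C)c2ccc(OCC3CCN(Cc4ccc(CO)cc4)CC3)cc2oc1=O` — 29 nM
compound 2 `Cc1cc(=O)oc2cc(OCC3CCN(Cc4ccc(CO)cc4)CC3)ccc12` — 600 nM
compound 3 `Cc1cc2ccc(OCC3CCN(Cc4ccc(CO)cc4)CC3)cc2oc1=O` — 3100 nM

All three were tested in an assay for inhibition of Amine oxidase [flavin-containing] B (Homo sapiens), read by fluorescence, using microsomes, with a stated time of 30 min; a higher number here means a weaker inhibitor, a lower number a stronger inhibitor. Compound 1 gives the lowest number of the three. The step of a 21-fold higher number from compound 1 to compound 2 (1.32 log units; beyond the scatter) and the step of a 110-fold higher number from compound 1 to compound 3 (2.03 log units; beyond the scatter) both concern hydrogen in place of methyl on an aromatic carbon of the shared core, and both lie beyond the scatter, so compound 1 stands well apart from compound 2 and compound 3.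

Compound 4 `Cc1c(C)c2ccc(OCC3CCN(Cc4cccc(CO[N+](=O)[O-])c4)CC3)cc2oc1=O` is not yet measured. It keeps the core of compound 1 with both methyl groups and differs only in the group on the saturated chain carbon bound to the amine nitrogen in the ring: 3-((nitrooxy)methyl)phenyl in place of 4-(hydroxymethyl)phenyl on a saturated chain carbon bound to an amine nitrogen in a ring. Neither measured step touches that part of the molecule; both concern the core methyls, so the series gives no direct guide to a change at the altered group. With the core of compound 1 intact, the expectation in this assay is a small step, a 1.4-fold higher number from compound 1 to compound 4 (0.14 log units; within the scatter), not clearly beyond the scatter, in either direction. Compound 4 is therefore estimated at 40 nM, with a range from 10 nM to 160 nM.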

Compound 4, half-maximal inhibitory concentration: 51 nM
Estimate against measurement, compound 4: 1.3-fold (0.11 log units) below, within the range that was stated.
By their numbers in this assay, from the lowest: compounds 1 and 4 (each within the scatter of the next); then compound 2; then compound 3.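

In this assay, the group on the saturated chain carbon bound to an amine nitrogen in a ring can be changed with little effect: 3-((nitrooxy)methyl)phenyl in place of 4-(hydroxymethyl)phenyl gives a 1.8-fold higher number from compound 1 to compound 4 (0.25 log units; within the scatter). Within the data shown here, this is the first reading at this place, and it stands apart from the two core methyl steps, which both lie beyond the scatter, even though the entering group has 11 heavy atoms against 8 and 0 hydrogen-bond donors against 1. Nothing available explains why this step stays so small.

The step changes the group and its numbered place on the phenyl together, and the two effects cannot be separated without 3-(hydroxymethyl)phenyl and 4-((nitrooxy)methyl)phenyl. Also open, from the compounds shown here alone, is how a carboxylic acid or an amine would read at this place, and whether the result carries over to the cores of compound 2 and compound 3.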